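The compounds below may be only part of what the source reports. "The series", "measured", "known", "first", "only" and "open" are said of these compounds alone.

Compound 1 `COC(=O)c1cc(-c2cnc(C(=O)CCc3ccc(-c4ccccc4)cc3)o2)ccn1` holds the lowest number of the two compounds measured in an assay for inhibition of Fatty-acid amide hydrolase 1 (Rattus norvegicus) (a lower number here means a stronger inhibitor, a higher number a weaker inhibitor), where compound 1 gives 1.5 nM. The other measured compound, compound 2 `CNC(=O)c1cnc(C(=O)CCc2ccc(Oc3ccccc3)cc2)o1`, gives 11 nM in this assay; the two differ in more than one place, so their values can only be set side by side, and compound 2 sits well beyond the scatter above compound 1.

The next compound, compound 3 `O=C(CCc1ccc(-c2ccccc2)cc1)c1ncc(-c2cccnc2)o1`, differs from compound 1 in a single place: pyridin-3-yl in place of 2-(methoxycarbonyl)pyridin-4-yl on an aromatic carbon. The leaving group carries a methoxycarbonyl, counted as one double bond outside aromatic rings, and three hydrogen-bond acceptors, whereas the entering pyridin-3-yl carries one hydrogen-bond acceptor and no such double bond.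

Going by the values given here, no measured pair shows this change on its own, so its effect cannot be read from the data. The expectation is a modest step toward a higher number, a 2.7-fold higher number from compound 1 to compound 3 (0.43 log units; beyond the scatter), which may not exceed the scatter. Compound 3 is estimated at 4 nM in this assay, within a range from 1 nM to 20 nM.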

Compound 3, inhibition constant: 1.1 nM
For compound 3 the middle estimate is 3.6-fold (0.56 log units) above the measured one, and the stated range covers the measured number.
By their numbers in this assay, from the lowest: compounds 3 and 1 (each within the scatter of the next); then compound 2.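

At this place on the five-membered aromatic ring, next to the ring oxygen, replacing 2-(methoxycarbonyl)pyridin-4-yl with pyridin-3-yl gives in this assay a 1.4-fold lower number from compound 1 to compound 3 (0.13 log units; within the scatter), so the measurement does not separate the two compounds. The methoxycarbonyl is therefore not required for a value of this size in this series, as compound 3 lacks it and still gives 1.1 nM, and a smaller pyridine substituent with fewer hydrogen-bond acceptors is tolerated here. No independent evidence is available to explain why the value holds across this change.

The step also bundles two differences, the loss of the methoxycarbonyl and a different point of attachment of the pyridine ring, as the two group names show, so the contribution of each cannot be read on its own. Also open, going by these compounds, is whether the value would hold with a carboxylic acid on the pyridine ring, or with a plain phenyl ring at this place, which would show whether the ring nitrogen matters at all.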